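Swapping a thiophene for a furan on a nucleoside core

The source may hold more compounds than are shown below. What is called first, only, known or untested is meant among the compounds shown, and "the series" means these compounds.

Measured so far in a functional assay on HepG2 cells (Homo sapiens) for antiproliferative activity, read by XTT assay, with a stated time of 72 h; on this read-out higher numbers stand for weaker inhibition and lower numbers for stronger inhibition:
Compound 1, `Nc1nc(N)c2c(-c3ccsc3)cn([C@@H]3O[C@H](CO)[C@@H](O)[C@H]3O)c2n1`: > 20000 nM
Compound 2, `O=c1[nH]cnc2c1c(-c1cccs1)cn2[C@@H]1O[C@H](CO)[C@@H](O)[C@H]1O`: > 20000 nM
Compound 3, `Cc1nc(N)c2c(-c3ccsc3)cn([C@@H]3O[C@H](CO)[C@@H](O)[C@H]3O)c2n1`: > 20000 nM

Each of these values is a limit of this assay rather than a number. Compound 1 therefore stands at that limit, and so do compound 2 and compound 3; (the limit of > 20000 nM in this assay, at which 3 of the 3 values shown sit). Within the data shown here, the only measured step that touches compound 1 is a step that the two limits leave unreadable from compound 1 to compound 3, which the two limits leave unreadable. Compound 4, `Nc1nc(N)c2c(-c3ccco3)cn([C@@H]3O[C@H](CO)[C@@H](O)[C@H]3O)c2n1`, differs from compound 1 by furan-2-yl in place of thiophen-3-yl on an aromatic carbon. Among the measured compounds shown here, no measured step bears on this change, so no direction beyond the scatter can be expected, and the step of a number no higher from compound 1 to compound 4 (the limit leaves the size open) is an estimate that compound 4 most likely remains at the limit. Compound 4 is therefore expected to give 20000 nM, within 5000 nM to 80000 nM.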

Compound 4, half-maximal inhibitory concentration: > 20000 nM
Compound 4 gave a limit, no number; the forecaster's own chance of this, stated with the estimate: 80%; the middle value sits exactly at the limit.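

Compound 1 and compound 4 both sit at a limit of this assay, not at a number, so the change from thiophen-3-yl to furan-2-yl cannot be read as a step. The compounds shown leave open how potent any of them really is, and which change to the shared core would give a readable number.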